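Adding a Second Chloro to a Purine-Type Core

The source may report more compounds than this note shows. Statements on the series, on what has been measured and on what is new or still open speak of the compounds shown alone.

Compound 1, with the structure `ClCc1ccc(Cn2cnc3c(Cl)ncnc32)cc1`, is the starting point of this piece, yet its result in a functional assay on HT-29 cells (Homo sapiens) for cytotoxicity, read by sulforhodamine B assay, with a stated time of 48 h (on this read-out higher numbers stand for lower toxicity in this test and lower numbers for higher toxicity in this test), is "not determined" (no result reported), so no single number places it on the scale. What is known comes from two relatives that carry two chloro groups on the shared core. Compound 2, with the structure `ClCc1cccc(Cn2cnc3c(Cl)nc(Cl)nc32)c1`, reaches only a limit of the assay in this assay, recorded as > 100000 nM. Compound 3, with the structure `ClCc1ccccc1Cn1cnc2nc(Cl)nc(Cl)c21`, likewise gives only a limit in this assay, recorded as > 100000 nM. Both therefore sit at the limit of > 100000 nM in this assay, at which 2 of the 3 values shown sit, which leaves the toxicity of the whole series unresolved at the upper end of the measured range.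

Compound 4, with the structure `ClCc1ccc(Cn2cnc3c(Cl)nc(Cl)nc32)cc1`, is compound 1 changed in one place: chloro in place of hydrogen on an aromatic carbon. The new chloro sits between two ring nitrogen atoms of the six-membered ring that holds two nitrogen atoms, so compound 4 shares the dichloro pattern of compound 2 and compound 3 while keeping the para arrangement on the benzyl ring of compound 1. With no number for compound 1, no step can be expected beyond a return to the same limit, and neither direction can be claimed. Compound 4 is therefore expected to give about 100000 nM in this assay, most likely again only as a limit, within a range from 60000 nM to 300000 nM.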

Compound 4, concentration lethal to 50% of the cells: > 100000 nM
Compound 4: a limit, no number; the forecaster's own chance of this, stated with the estimate: 85%; the middle value sits exactly at the limit.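

In this assay compound 4 gives > 100000 nM, which is a limit of the assay and not a number. Going by these compounds alone, compound 1 has no number on this scale, so no step from compound 1 to compound 4 can be read. The compounds shown leave open whether the added chloro changes the toxicity in this assay, and what the actual lethal concentration of any of them is.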